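Trading a Dimethylamino Group for Fluoro

This account rests on a few compounds, and the source may have more. Where it says the series, first, only, none or still open, it means among the compounds named here.

Compound 2 `C[C@H]1CC[C@@H]2[C@@H](OC(=O)[C@]23CC(c2ccc(N(C)C)cc2)=NO3)[C@]2(C)C(=O)C=C[C@@]12O` holds the lowest of the two numbers measured in a functional assay on SW-620 cells (Homo sapiens) for cytotoxicity, read by sulforhodamine B assay, with a stated time of 48 h (on this read-out higher numbers stand for weaker inhibition and lower numbers for stronger inhibition), giving 5100 nM. Its nearest neighbour is compound 1 `C[C@H]1CC[C@@H]2[C@@H](OC(=O)[C@]23CC(c2ccc(Cl)cc2)=NO3)[C@]2(C)C(=O)C=C[C@@]12O`, which in this assay gives 51000 nM. Among the measured compounds shown here, the single measured step, a 10-fold lower number from compound 1 to compound 2 (1.00 log units; beyond the scatter), shows that putting dimethylamino in place of chloro on the aromatic carbon lowered the number. Compound 3 `C[C@H]1CC[C@@H]2[C@@H](OC(=O)[C@]23CC(c2ccccc2F)=NO3)[C@]2(C)C(=O)C=C[C@@]12O` removes that dimethylamino group: 2-fluorophenyl in place of 4-(dimethylamino)phenyl on a carbon with a double bond to nitrogen. For the measured compounds named here, since the only step on hand ties dimethylamino to the lower number, compound 3 is expected to move back toward compound 1, by about a 5.9-fold higher number from compound 2 to compound 3 (0.77 log units; beyond the scatter). The estimate for compound 3 is therefore 30000 nM, with a range from 8000 nM to 100000 nM.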

Compound 3, half-maximal inhibitory concentration: 11000 nM
Estimate against measurement, compound 3: 2.7-fold (0.44 log units) above, within the range that was stated.
By their numbers in this assay, from the lowest: compound 2; then compound 3; then compound 1.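

Removing dimethylamino does not restore the weaker value of compound 1: a 2.2-fold higher number from compound 2 to compound 3 (0.33 log units; beyond the scatter), yet a 4.6-fold lower number from compound 1 to compound 3 (0.67 log units; beyond the scatter). The lower number at this position therefore does not require 4-(dimethylamino)phenyl, and 2-fluorophenyl places compound 3 between the other two. Nothing available explains this order.

Because 2-fluorophenyl and 4-chlorophenyl differ in both halogen and ring position, the second step cannot be assigned to either change alone. On these data alone, whether a methoxy group or a carboxylic acid on the phenyl ring would lower the number further remains open.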